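The compounds below may be only part of what the source reports. "The series", "measured", "known", "first", "only" and "open" are said of these compounds alone.

Measured so far in an ADME assay on microsomes from liver (Homo sapiens) for metabolic stability, read by LC-MS, with a stated time of 30 min, tested at 1 uM (on this read-out higher numbers stand for a more stable compound and lower numbers for a less stable compound), are two compounds:

compound 1 `O=C(NCc1ccc(S(=O)(=O)c2ccccc2)cc1)c1cc2ncccc2s1` gives 81% in this assay
compound 2 `O=C(NCc1ccc(S(=O)(=O)c2cc(F)cc(F)c2)cc1)c1cc2cnccc2[nH]1` gives 82% in this assay

Compound 2 at 82% and compound 1 at 81% lie within the usual scatter of each other, so the two cannot be told apart on these numbers.

Next comes compound 3 `O=C(NCc1ccc(S(=O)(=O)c2ccccc2)cc1)c1cc2cnccc2[nH]1`, which has not yet been measured. It keeps the core of compound 2 and alters one group. The change is phenyl in place of 3,5-difluorophenyl on a sulfonyl sulfur and in words it is phenyl in place of 3,5-difluorophenyl on a sulfonyl sulfur.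

Among the compounds with values here, no measured pair isolates this change. Compound 1 carries phenyl on its sulfonyl sulfur, on a different core, and gives 81% in this assay with no sign of a low value. That single comparison suggests no step beyond the scatter. The expected step of a number 5 percentage points lower from compound 2 to compound 3 (within the scatter) is estimated to stay within the usual scatter, with any drift expected to be slightly downward. For compound 3 the estimated value is 77% with an expected range from 62% to 90% in this read-out.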

Compound 3, percent of the compound remaining: 75%
For compound 3 the middle estimate is 2 percentage points above the measured one, and the stated range covers the measured number.
By their numbers in this assay, from the lowest: compounds 3, 1 and 2 (each within the scatter of the next).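

In this assay, within the data shown here, the step of a number 7 percentage points lower from compound 2 to compound 3 (within the scatter) is the first reading on a single change at this position, and it shows that on the core of compound 2 the two fluorines of 3,5-difluorophenyl can give way to plain phenyl on a sulfonyl sulfur without a step that stands clear of the scatter. With phenyl held constant on the sulfonyl sulfur, the step of a number 6 percentage points lower from compound 1 to compound 3 (within the scatter) adds a second single-place reading, this time on the carbonyl carbon, where exchanging one group of 9 heavy atoms for the other also stays inside the scatter of this assay and so gives no separation between the two cores. No supporting measurement is available that could account for either step.

Still open, going by these compounds, is whether a group of another kind on the sulfonyl sulfur, such as an amine, a morpholine or a carboxylic acid, would move the read-out beyond the scatter. Also open, on these data alone, is whether phenyl in place of 3,5-difluorophenyl gives a similar step on the core of compound 1, since this change has been read on one core only.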